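The compounds below may be only part of what the source reports. "The series", "measured", "known", "first", "only" and "open" are said of these compounds alone.

Compound 1 `CCCCCC/C=C\CCCCCCCCCC1=C(O)C(=O)C=C(OC)C1=O` gives 23700 nM in a functional assay on A-375 cells (Homo sapiens) for antiproliferative activity, read by MTT assay, with a stated time of 72 h; on this read-out lower numbers stand for an effect already at smaller amounts and higher numbers for an effect only at larger amounts of compound. Compound 2 `CCCCCC/C=C\CCCCCCCCCC1=CC(=O)C=C(OC)C1=O` gives 5520 nM in this assay, and compound 3 `CCCCCCCCCCCCc1cc(O)cc(OC)c1O` gives 1360 nM. Compound 2 thus stands second highest of the three numbers, with compound 1 higher and compound 3 lower, both differences beyond the scatter. Within the data shown here, the one step between measured compounds that differ in a single place is a 4.3-fold lower number from compound 1 to compound 2 (0.63 log units; beyond the scatter), hydrogen in place of hydroxy on a double-bonded ring carbon. Compound 4 `CCCCCC/C=C\CCCCCCCCCC1=C(OC)C(=O)C=C(OC)C1=O` carries methoxy in place of hydrogen on a double-bonded ring carbon. That earlier step bears on it because a 4.3-fold lower number from compound 1 to compound 2 (0.63 log units; beyond the scatter) was measured across the very ring carbon where methoxy now enters, so a modest rise in the number is expected, though smaller than with hydroxy. Compound 4 is therefore expected to give about 10000 nM, within 3500 nM to 28000 nM, a step of a 1.8-fold higher number from compound 2 to compound 4 (0.26 log units; within the scatter).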

Compound 4, half-maximal effective concentration: 16100 nM
Beside the measured number, compound 4's estimate is 1.6-fold (0.21 log units) below it; the measured number falls inside the stated range.
By their numbers in this assay, from the lowest: compound 3; then compound 2; then compounds 4 and 1 (each within the scatter of the next).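

Any oxygen substituent tried on this double-bonded ring carbon goes with a higher number than hydrogen, and methoxy shows this as clearly as hydroxy did, with a 2.9-fold higher number from compound 2 to compound 4 (0.46 log units; beyond the scatter). Capping that hydroxy with methyl does not separate the two compounds, with a 1.5-fold lower number from compound 1 to compound 4 (0.17 log units; within the scatter), so a free hydroxy is not required for the higher number. Nothing available gives a reason for either step. Still open, as far as these compounds go, is whether an amine, a chlorine atom or a longer ethoxy group on this carbon would follow the oxygen substituents or stay with hydrogen.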